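A Bicyclic Amine in Place of Methylpyrrolidine

A few compounds are considered here, and "the series" means these few. Any claim that something is new, unique, unknown or untested is made for them only; others in the source may bear on it.

Measured so far:
Compound 1, `O=C(CCc1ccc(C(F)(F)F)cc1)Nc1ccc2nc(N3CCC(NS(=O)(=O)O)C3)ccc2c1`, gives 50 nM in a functional assay on HEK293 cells for activation of melanin-concentrating hormone receptor 1 (Rattus norvegicus), read by inositol phosphate accumulation; a higher number here means that more compound is needed for the effect, a lower number that less compound is needed.
Compound 2, `CC1CCCN1c1ccc2cc(NC(=O)CCc3ccc(C(F)(F)F)cc3)ccc2n1`, gives 270 nM in this assay.
Compound 3, `O=C(CCCCCCCCCCCCc1ccc(C(F)(F)F)cc1)Nc1ccc2nc([N+]34CCC(CC3)CC4)ccc2c1`, gives 25 nM in this assay.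

Compound 2 holds the highest number of the three. Its nearest neighbour is compound 1: exchanging 3-(sulfoamino)pyrrolidin-1-yl for 2-methylpyrrolidin-1-yl on the aromatic carbon gives a 5.4-fold higher number from compound 1 to compound 2 (0.73 log units; beyond the scatter). Compound 3 lies further away, but it differs from compound 2 in two places at once, the group on that aromatic carbon and the length of the chain, so its value only shows that a lower number is reachable on this shared core.

Compound 4, `O=C(CCc1ccc(C(F)(F)F)cc1)Nc1ccc2nc(N3CC4CC3CO4)ccc2c1`, is not yet measured. It differs from compound 2 in one place: a group of 7 heavy atoms (5 carbon, 1 nitrogen, 1 oxygen; 2 five-membered non-aromatic rings with 1 hetero atom each) in place of a group of 6 heavy atoms (5 carbon, 1 nitrogen; one five-membered non-aromatic ring with 1 hetero atom), on an aromatic carbon. A single measured step touches the same position, a 5.4-fold higher number from compound 1 to compound 2 (0.73 log units; beyond the scatter), and it is modest. The group entering in compound 4 resembles neither end of that step closely: a second ring and an oxygen come in, with no donor and no charge. The data give no direct guide, so no step beyond the scatter is expected.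

Compound 4 is therefore expected to give about 200 nM in this assay, most likely between 60 nM and 650 nM. The estimated step of a 1.4-fold lower number from compound 2 to compound 4 (0.13 log units; within the scatter) is expected to remain within the scatter.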

Compound 4, half-maximal effective concentration: 70 nM
For compound 4 the middle estimate is 2.9-fold (0.46 log units) above the measured one; the measured number falls inside the stated range.
By their numbers in this assay, from the lowest: compounds 3, 1 and 4 (each within the scatter of the next, the first and the last beyond it); then compound 2.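

In this assay, the step away from the 2-methylpyrrolidin-1-yl group on this aromatic carbon is now seen with a second replacement: the two-ring group of compound 4, which carries no net charge, gives a 3.9-fold lower number from compound 2 to compound 4 (0.59 log units; beyond the scatter). Set against the 3-(sulfoamino)pyrrolidin-1-yl group, the same two-ring group gives a 1.4-fold higher number from compound 1 to compound 4 (0.15 log units; within the scatter), so on this shared core the sulfoamino group is not required to reach the level of compound 1. No measurement is available that would explain either step.

In compound 4 the oxygen and the second ring enter together, so the compounds shown cannot say which of them matters, and a two-ring group made only of carbon and nitrogen, or a simple morpholine, would be needed to pull the two apart. It also remains open whether the group of compound 4 would keep its value when joined to the longer chain of compound 3, since no pair shown varies the chain alone.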